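Ester Chain Swap on a Shared Core: An Expected Potency

A few compounds are considered here, and "the series" means these few. Any claim that something is new, unique, unknown or untested is made for them only; others in the source may bear on it.

Compound 2 `COC(=O)C1=C(C)NC(C)=C(C(=O)OCC(F)(F)F)C1c1cccc([N+](=O)[O-])c1`: 16 nM
Compound 1 `CCCC1=C(C(=O)OCC)C(c2cccc([N+](=O)[O-])c2)C(C(=O)OCC)=C(C)N1`: 18 nM

In a functional assay on HEK293 cells for antagonist activity at Voltage-dependent L-type calcium channel subunit alpha-1C (Oryctolagus cuniculus), read by FLIPR (on this read-out higher numbers stand for weaker inhibition and lower numbers for stronger inhibition), compound 2 gives 16 nM, the lowest of the two numbers, while compound 1 gives 18 nM, which lies within the scatter of it, so the two cannot be told apart. Compound 3 `COC(=O)C1=C(C)NC(C)=C(C(=O)OCCCCc2ccc(OC)cc2)C1c1cccc([N+](=O)[O-])c1` is not yet measured. It differs from compound 2 in one place: 3-(4-methoxyphenyl)propyl in place of trifluoromethyl on a saturated chain carbon bound to an oxygen next to a carbonyl group. Going by the values given here, no measured pair shows a change of this kind, so the step can only be estimated; a small step toward stronger inhibition, or none beyond the scatter, is expected: a 1.6-fold lower number from compound 2 to compound 3 (0.20 log units; within the scatter). Compound 3 is estimated at 10 nM, within 3 nM to 40 nM.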

Compound 3, half-maximal inhibitory concentration: 17 nM
Compound 3: the middle estimate sits 1.7-fold (0.23 log units) below what was measured; measured number inside the range.
By their numbers in this assay, from the lowest: compounds 2, 3 and 1 (each within the scatter of the next).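

In this assay, 3-(4-methoxyphenyl)propyl in place of trifluoromethyl on this saturated chain carbon gives a 1.1-fold higher number from compound 2 to compound 3 (0.03 log units; within the scatter). The entering group has 11 heavy atoms and a six-membered aromatic ring, while the leaving group has 4 heavy atoms and no ring, yet inhibition shows no readable change. At this position, then, a far larger group is tolerated, at least for this one pair. Going by these compounds, whether an amine or a carboxylic acid at the end of this chain would also leave inhibition unchanged stays open. Nothing shown here explains why these two groups give such close numbers.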